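From Cyclopropylamino to 1,4-Diazepan-1-yl on the Carbonyl

The source may report more compounds than this note shows. Statements on the series, on what has been measured and on what is new or still open speak of the compounds shown alone.

In a functional assay on LNCaP cells (Homo sapiens) for antiproliferative activity, read by MTT assay, with a stated time of 3 days (a lower number here means a stronger inhibitor, a higher number a weaker inhibitor), compound 1 (`COc1cc(O)c2c(=O)cc(-c3ccc(NS(C)(=O)=O)cc3)oc2c1OC(C)C`) gives 15400 nM and compound 2 (`COc1cc(O)c2c(=O)cc(-c3ccc(NC(=O)NC4CC4)cc3)oc2c1OC(C)C`) gives 13800 nM, which places the two within the scatter of each other. Compound 3 (`COc1cc(O)c2c(=O)cc(-c3ccc(NC(=O)N4CCCNCC4)cc3)oc2c1OC(C)C`) has 1,4-diazepan-1-yl in place of cyclopropylamino on a carbonyl carbon. Within the data shown here, only one measured step bears on this change, a 1.1-fold lower number from compound 1 to compound 2 (0.05 log units; within the scatter), and it lies within the scatter. Among the measured compounds shown here, no measured compound carries the new ring. The expected step of a 1.2-fold lower number from compound 2 to compound 3 (0.06 log units; within the scatter) is therefore estimated to stay within the scatter, with neither direction favoured. The estimate for compound 3 is 12000 nM, with an expected range of 4000 nM to 30000 nM.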

Compound 3, half-maximal inhibitory concentration: 22500 nM
Compound 3: the middle estimate sits 1.9-fold (0.27 log units) below what was measured, within the range that was stated.
By their numbers in this assay, from the lowest: compounds 2, 1 and 3 (each within the scatter of the next).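

In this assay, the larger 1,4-diazepan-1-yl ring on the carbonyl carbon brings no step beyond the scatter, with a 1.6-fold higher number from compound 2 to compound 3 (0.21 log units; within the scatter). The (1,4-diazepan-1-yl)carbonyl group in place of methylsulfonyl on the nitrogen likewise gives a 1.5-fold higher number from compound 1 to compound 3 (0.16 log units; within the scatter), so all three groups shown at this position read alike. No evidence at hand bears on this result. Going by these compounds, whether an open-chain dimethylamino group or a carboxylic acid-bearing chain on the carbonyl carbon would move the number beyond the scatter remains open.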